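Working notes: compound 3 to compound 4

The compounds below may be only part of what the source reports. "The series", "measured", "known", "first", "only" and "open" are said of these compounds alone.

Measured so far in an ADME assay on the whole organism (plasma, Rattus norvegicus, strain Sprague-Dawley) for pharmacokinetics, read by LC-MS, using cassette dosing, at a dose of 0.2 mg/kg by the intravenous route (a higher number here means more compound in the circulation at the dose given, a lower number less compound in the circulation), for the series
- Compound 1 `CNCc1cn(S(=O)(=O)c2cccc(OC)n2)c(-c2cccnc2F)c1F` gives 50 ng.h/mL
- Compound 2 `CNCc1cn(S(=O)(=O)c2cccnc2C)c(-c2cccnc2F)c1F` gives 32 ng.h/mL
- Compound 3 `CNCc1cn(S(=O)(=O)c2cncc(C)c2)c(-c2cccnc2F)c1F` gives "not determined" (no result reported)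

Compound 3 has no number to stand on, with "not determined" (no result reported) as its entry, so it offers no starting value. Compound 4 `CNCc1cn(S(=O)(=O)c2ccc(C)nc2)c(-c2cccnc2F)c1F` has the same atoms as compound 3, joined differently, with 6-methylpyridin-3-yl in place of 5-methylpyridin-3-yl on a sulfonyl sulfur as the change. It puts 6-methylpyridin-3-yl in place of 5-methylpyridin-3-yl on a sulfonyl sulfur. Among the measured compounds shown here, the one measured step that bears on this, also an exchange on a sulfonyl sulfur, is a 1.6-fold lower number from compound 1 to compound 2 (0.19 log units; within the scatter) and it lies within the scatter. Neither group in the new change takes part in that step, so the evidence is thin. No step beyond the scatter is expected in this assay and no direction can be given. For the measured compounds named here, the estimate therefore rests on compound 1 at 50 ng.h/mL and compound 2 at 32 ng.h/mL as the only numbers. Compound 4 is expected at 40 ng.h/mL with an estimated range from 15 ng.h/mL to 100 ng.h/mL as the likely span.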

Compound 4, area under the concentration-time curve: 41 ng.h/mL
The estimate for compound 4 lay 1.0-fold (0.01 log units) below the measured number; measured number inside the range.
By their numbers in this assay, from the lowest: compounds 2, 4 and 1 (each within the scatter of the next).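

In this assay, the exchange on a sulfonyl sulfur gives a 1.3-fold higher number from compound 2 to compound 4 (0.11 log units; within the scatter) with 6-methylpyridin-3-yl in place of 2-methylpyridin-3-yl, and a 1.2-fold lower number from compound 1 to compound 4 (0.09 log units; within the scatter) with 6-methylpyridin-3-yl in place of 6-methoxypyridin-2-yl. The series thus gains a third group at this place, and every readable step among the three groups lies within the scatter, while the step from compound 3 to compound 4 cannot be read. No measurement at hand accounts for any of these steps.

As far as these compounds go, whether 5-methylpyridin-3-yl and 6-methylpyridin-3-yl differ at all in this assay stays open. Also open, from the compounds shown here alone, is whether an amine or a carboxylic acid in place of these groups on a sulfonyl sulfur would give a step beyond the scatter.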